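Isobutoxy to butoxy on the shared core

The compounds below may be only part of what the source reports. "The series", "measured", "known", "first", "only" and "open" are said of these compounds alone.

Compound 1 `Oc1ccc2nc(-c3ccccc3)cc(O)c2c1` gives in a functional assay on HCT-8 cells (Homo sapiens) for cytotoxicity (a lower number here means that less compound is needed, a higher number that more compound is needed for the effect), a value of 7.75 ug/mL. Compound 2 `CC(C)COc1cc(-c2ccccc2)nc2ccccc12` gives in this assay only a limit, > 10 ug/mL, which is the limit of > 10 ug/mL in this assay, at which 1 of the 2 values shown sits. Compound 2 therefore stands at the limit of this assay and not at a number. Compound 3 `CCCCOc1cc(-c2ccccc2)nc2ccccc12` is not yet measured and differs from compound 2 by propyl in place of isopropyl on a saturated chain carbon bound to an oxygen on an aromatic ring. No step between measured compounds is shown here, so from compound 2 to compound 3 a step within the scatter, in no fixed direction, is expected a step that the limit leaves unreadable from compound 2 to compound 3. Compound 3 is expected near 12 ug/mL, between 5 ug/mL and 30 ug/mL, most likely again reported as a limit.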

Compound 3, half-maximal effective concentration: > 10 ug/mL
Compound 3 gave a limit, no number (the forecaster's own chance of this, stated with the estimate: 65%); the middle value is on the limit's open side.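

Compound 2 and compound 3 both stand only as limits in this assay, so no step between them can be read: the limit of > 10 ug/mL in this assay, at which 2 of the 3 values shown sit.

From the compounds shown here alone, whether isobutoxy and butoxy on the shared core differ at all in this read-out remains open.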